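A few compounds are considered here, and "the series" means these few. Any claim that something is new, unique, unknown or untested is made for them only; others in the source may bear on it.

Compound 1, `Cc1cccc(NC(=O)C2(C(=O)Nc3ccc(Nc4ncc5cc(C(=O)N(C)C)n(C6CCCC6)c5n4)cc3)CC2)c1`, gives 86.1% in a functional assay on A549 cells (Homo sapiens) for inhibition, read by CCK-8 assay, with a stated time of 72 h, tested at 10 uM; a lower number here means less inhibition of growth, a higher number more inhibition of growth at the concentration tested.
Compound 2, `COC(=O)c1ccc(NC(=O)C2(C(=O)Nc3ccc(Nc4ncc5cc(C(=O)N(C)C)n(C6CCCC6)c5n4)cc3)CC2)cc1`, gives 92% in this assay.
Compound 3, `CN(C)C(=O)c1cc2cnc(Nc3ccc(NC(=O)C4(C(=O)Nc5cccc(F)c5)CC4)cc3)nc2n1C1CCCC1`, gives 91.8% in this assay.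

Compound 2 holds the highest of the three numbers, but only by steps that lie within the scatter: a number 5.9 percentage points higher from compound 1 to compound 2 (within the scatter) and a number 0.2 percentage points lower from compound 2 to compound 3 (within the scatter), so the three compounds stand level. Compound 4, `COc1ccc(NC(=O)C2(C(=O)Nc3ccc(Nc4ncc5cc(C(=O)N(C)C)n(C6CCCC6)c5n4)cc3)CC2)cc1`, differs from compound 2 in one place: methoxy in place of methoxycarbonyl on an aromatic carbon. The two measured steps just named are the ones that bear on this exchange, since each also swaps the group carried on the same amide-type nitrogen, and neither moved the growth inhibition beyond the scatter. No step beyond the scatter is therefore expected here either; the expected change is a number 2 percentage points lower from compound 2 to compound 4 (within the scatter). Compound 4 is estimated at 90%, with a range from 82% to 96%.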

Compound 4, percent growth inhibition at one concentration: 78.5%
Compound 4: the middle estimate sits 11.5 percentage points above what was measured; measured number outside the range, below it.
By their numbers in this assay, from the lowest: compounds 4, 1, 3 and 2 (each within the scatter of the next, the first and the last beyond it).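

In this assay methoxy in place of methoxycarbonyl at this carbon, para to a large group, gives a number 13.5 percentage points lower from compound 2 to compound 4 (beyond the scatter) and so shows that this ring substituent can matter. The same 4-methoxyphenyl group gives a number 13.3 percentage points lower from compound 3 to compound 4 (beyond the scatter) but only a number 7.6 percentage points lower from compound 1 to compound 4 (within the scatter) and so stands level with the 3-methylphenyl of compound 1, which means the loss does not appear against every partner. Nothing measured here gives a reason for this drop.

The compounds shown leave open how a carboxylic acid or an amine at this same carbon would compare with the methoxycarbonyl of compound 2.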